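Methoxy for Methyl on the Pendant Phenyl Ring

The source may hold more compounds than are shown below. What is called first, only, known or untested is meant among the compounds shown, and "the series" means these compounds.

Measured so far:
compound 1 `CCCCCc1c(C(C)C)nc(C(C)C)c(CO)c1-c1ccc(OC)cc1`: 37%
compound 2 `CCCCCc1c(C(C)C)nc(C(C)C)c(CO)c1-c1ccccc1C`: 33%

Two compounds share a core and differ only in the aryl group attached to it. In an assay on CHO cells for inhibition of Glucagon receptor (Homo sapiens), tested at 20 uM (a lower number here means less inhibition, a higher number more inhibition at the concentration tested (going by the name of the read-out)), compound 1 gives 37%. In this assay compound 2 gives 33%, and the step of a number 4 percentage points lower from compound 1 to compound 2 (within the scatter) shows that these two values cannot be told apart. Compound 3 `CCCCCc1c(C(C)C)nc(C(C)C)c(CO)c1-c1ccccc1OC` is the next compound to be measured. Its change from compound 2 is methoxy in place of methyl on an aromatic carbon. Among the compounds with values here, the only measured step, a number 4 percentage points lower from compound 1 to compound 2 (within the scatter), also moved between a methyl and a methoxy on this ring, though at a different ring position together with that position, and it stayed inside the scatter. On that basis the step is expected to be a number 2 percentage points higher from compound 2 to compound 3 (within the scatter), nothing beyond the scatter in either direction. Compound 3 is therefore estimated at 35%, with a range from 22% to 48%.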

Compound 3, a percentage reported as inhibition, at one concentration (the size of the read-out at that concentration, not a potency): 27%
The estimate for compound 3 lay 8 percentage points above the measured number; low and high end bracket the measured number.
By their numbers in this assay, from the lowest: compounds 3, 2 and 1 (each within the scatter of the next).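

Methoxy in place of methyl on the aromatic carbon ortho to a large group gives a number 6 percentage points lower from compound 2 to compound 3 (within the scatter) in this assay, so this direct comparison of the two groups at one position shows no difference that can be read. Changing 4-methoxyphenyl to 2-methoxyphenyl gives a number 10 percentage points lower from compound 1 to compound 3 (within the scatter), which adds a comparison of the methoxy group at two ring positions, and that difference cannot be read either. The earlier step could not separate these questions, as the group and its position changed together.

Going by these compounds, whether any group at this carbon can move the number beyond the scatter remains open. Within the data shown here, an amine, a carboxylic acid or a longer chain such as ethoxy could test this, since methyl and methoxy are the only groups compared here. Nothing available explains the values of these three compounds.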